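Methoxy on compound 3: expected step

The source may report more compounds than this note shows. Statements on the series, on what has been measured and on what is new or still open speak of the compounds shown alone.

In a functional assay on HeLa cells (Homo sapiens) for antiproliferative activity, with a stated time of 48 h (a lower number here means a stronger inhibitor, a higher number a weaker inhibitor), compound 3 `C=C(Br)C(=O)Nc1ccc(C(=O)/C=C/c2ccccc2)cc1` gives 960 nM as its value. Compound 1 `C=C(Br)C(=O)Nc1ccc(/C=C/C(=O)c2ccc(OC)cc2)cc1` at 1400 nM lies within the scatter of compound 3. Compound 2 `C=C(Br)C(=O)Nc1ccc(/C=C/C(=O)c2cccs2)cc1` at 340 nM has a lower number than compound 3 by more than the scatter.

Compound 4 `C=C(Br)C(=O)Nc1ccc(C(=O)/C=C/c2ccc(OC)cc2)cc1` differs from compound 3 by one change methoxy in place of hydrogen on an aromatic carbon with methoxy in place of hydrogen on an aromatic carbon, para to a large group. Among the measured compounds shown here, the only measured step with any bearing is a 4.1-fold lower number from compound 1 to compound 2 (0.61 log units; beyond the scatter) for thiophen-2-yl in place of 4-methoxyphenyl on a carbonyl carbon. That step is modest and is a different exchange, so it guides the size only loosely. For the measured compounds named here, no measured pair isolates methoxy in place of hydrogen. No step beyond the scatter is therefore expected in this assay and no firm direction can be assigned. The expected step is a 1.2-fold lower number from compound 3 to compound 4 (0.08 log units; within the scatter) and it stays within the scatter. The estimate for compound 4 is 800 nM with 300 nM to 2000 nM as the expected range.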

Compound 4, half-maximal inhibitory concentration: 310 nM
Estimate against measurement, compound 4: 2.6-fold (0.41 log units) above; low and high end bracket the measured number.
By their numbers in this assay, from the lowest: compounds 4 and 2 (each within the scatter of the next); then compounds 3 and 1 (each within the scatter of the next).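

In this assay, among the compounds shown here, the exchange of phenyl for 4-methoxyphenyl gives a 3.1-fold lower number from compound 3 to compound 4 (0.49 log units; beyond the scatter), and this is the first step that isolates this change. The aromatic carbon para to a large group therefore responds to substitution, and an addition of only 2 heavy atoms, with no ring and no net charge, is enough to move the number beyond the scatter. No measurement among the data shown accounts for this step.

On these data alone, whether the step is specific to methoxy remains open, and a hydroxyl, a chlorine, an ethoxy or a dimethylamino group at the same place would test this. As far as these compounds go, it is also open whether the same exchange would give a step of similar size on the core of compound 1, where the 4-methoxyphenyl sits on a carbonyl carbon.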